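Cinnamic acid triazole series: swapping the aryl on the triazole

The source may report more compounds than this note shows. Statements on the series, on what has been measured and on what is new or still open speak of the compounds shown alone.

Measured compounds:
- compound 2 `COc1ccc(/C=C\C(=O)O)c(OCc2cn(-c3ccc(CO)cc3)nn2)c1CC=C(C)C`: 27100 nM
- compound 3 `COc1ccc(/C=C\C(=O)O)c(OCc2cn(-c3ccc(NC(=O)c4ccccc4)cc3)nn2)c1CC=C(C)C`: 17200 nM
- compound 1 `COc1ccc(/C=C\C(=O)O)c(OCc2cn(-c3ccccc3C(=O)N3CCC(O)C3)nn2)c1CC=C(C)C`: "not determined" (no result reported)

All four compounds share one core and differ only in the aryl group that sits on the triazole nitrogen. In a functional assay on NCI-H322 cells (Homo sapiens) for cytotoxicity, read by MTT assay, with a stated time of 24 h (on this read-out higher numbers stand for weaker inhibition and lower numbers for stronger inhibition), compound 2 gives 27100 nM and compound 3 gives 17200 nM. Compound 2 stands at the highest of the two numbers, but its nearest neighbour is compound 3 at a 1.6-fold lower number from compound 2 to compound 3 (0.20 log units; within the scatter), so the two cannot be told apart. Compound 1 has no reported result.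

The step to compound 4 `COc1ccc(/C=C\C(=O)O)c(OCc2cn(-c3ccccc3F)nn2)c1CC=C(C)C` is 2-fluorophenyl in place of 4-(hydroxymethyl)phenyl on an aromatic nitrogen. Within the data shown here, no measured step touches a 2-fluorophenyl group, so the only guide is the step from compound 2 to compound 3, which was within the scatter. On that basis compound 4 is expected to stay close to compound 2, with a step of about a 1.1-fold lower number from compound 2 to compound 4 (0.04 log units; within the scatter) in this assay. Compound 4 is therefore estimated at 25000 nM, somewhere between 10000 nM and 60000 nM.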

Compound 4, half-maximal inhibitory concentration: 45600 nM
Compound 4: middle estimate off by 1.8-fold (0.26 log units), on the low side, within the range that was stated.
By their numbers in this assay, from the lowest: compounds 3, 2 and 4 (each within the scatter of the next, the first and the last beyond it).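

In this assay, putting 2-fluorophenyl in place of 4-(hydroxymethyl)phenyl gives a 1.7-fold higher number from compound 2 to compound 4 (0.23 log units; within the scatter), even though the entering group has 0 hydrogen-bond donors and 0 hydrogen-bond acceptors and the leaving group has 1 of each. So at this position on the triazole nitrogen, this exchange of aryl groups gives no change that can be told from the scatter. The values do now span a little more, since compound 3 at 17200 nM and compound 4 at 45600 nM lie beyond the scatter of each other, while compound 2 lies within the scatter of both. Nothing available explains this result.

The compounds shown leave open what an amine or a carboxylic acid on the aryl ring would do to the number in this assay. They also leave open whether a chlorine or a methyl group would give a result like that of the fluorine.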